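Swapping a benzylic sulfide for an aryl sulfide

The source may hold more compounds than are shown below. What is called first, only, known or untested is meant among the compounds shown, and "the series" means these compounds.

Compound 1 `O=C(/C(=C\c1ccccc1OCc1ccccc1)SCc1ccc(Cl)c(Cl)c1)c1ccc(Cl)cc1` gives 10000 nM in a functional assay on DU-145 cells (Homo sapiens) for inhibition, read by trypan blue exclusion, with a stated time of 96 h; on this read-out lower numbers stand for stronger inhibition of growth and higher numbers for weaker inhibition of growth. It stands level with compound 2 `Cc1ccc(S/C(=C/c2c[nH]c3ccccc23)C(=O)c2ccc(Cl)cc2)cc1`, which gives 10000 nM, and with compound 3 `COc1ccccc1/C=C(/SCc1ccc(Cl)c(Cl)c1)C(=O)c1ccc(Cl)cc1`, which gives 10000 nM. Among the measured compounds shown here, the only single-point step measured, from compound 1 to compound 3, shows no change at the digits printed from compound 1 to compound 3 (within the scatter). Compound 4 `COc1ccc(S/C(=C/c2ccccc2OCc2ccccc2)C(=O)c2ccc(Cl)cc2)cc1` differs from compound 1 in one place: 4-methoxyphenyl in place of 3,4-dichlorobenzyl on a sulfur. For the measured compounds named here, no measured step covers this exact change, but compound 2, which also carries an aromatic ring directly on the sulfur, gives 10000 nM. Compound 4 is therefore expected to show no change at the digits printed from compound 1 to compound 4 (within the scatter) in this assay, and its estimated value is 10000 nM, ranging from 5000 nM to 20000 nM.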

Compound 4, concentration for 50% growth inhibition: 1000 nM
Compound 4: middle estimate off by 10-fold (1.00 log units), on the high side; the whole stated range lies above it.
By their numbers in this assay, from the lowest: compound 4; then compounds 1, 2 and 3 (each within the scatter of the next).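

Among the compounds shown here, putting 4-methoxyphenyl in place of 3,4-dichlorobenzyl on the sulfur gives a 10-fold lower number from compound 1 to compound 4 (1.00 log units; beyond the scatter) in this assay and is the first step here beyond the scatter. The earlier step, no change at the digits printed from compound 1 to compound 3 (within the scatter), showed no such shift, so the group on this sulfur can alter growth inhibition. No evidence is given on the cause of this step.

Going by these compounds, it remains open whether a 4-methoxybenzyl group on the sulfur would match compound 4, which would separate the effect of the methoxy group from that of the ring sitting directly on the sulfur. Also open, on these data alone, is how an amine in place of that methoxy group would behave.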